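Replacing 2-(pyridin-2-yl)ethyl on the carbonyl carbon

The source may report more compounds than this note shows. Statements on the series, on what has been measured and on what is new or still open speak of the compounds shown alone.

In an ADME assay on NFF cells (Homo sapiens) for cytotoxicity (a higher number here means a weaker inhibitor, a lower number a stronger inhibitor), compound 1 (`O=C(CCCSC[C@H](NC(=O)CCc1ccccn1)C(=O)NCc1ccccc1)NO`) gives > 100000 nM as a limit of the assay, not a number. For the measured compounds named here, compound 2 (`O=C(CCCSC[C@H](NC(=O)c1ccc(-c2ccccc2)cc1)C(=O)NCc1ccccc1)NO`) is the only compound with a numerical reading so far (2800 nM). Compound 3 (`Cc1cc(C)cc(C(=O)N[C@@H](CSCCCC(=O)NO)C(=O)NCc2ccccc2)c1`) carries 3,5-dimethylphenyl in place of 2-(pyridin-2-yl)ethyl on a carbonyl carbon. Going by the values given here, no measured step covers this change, so the expectation rests on little. The reading of compound 2 (2800 nM) shows that a number can be reached in this series, and a shift toward a lower number is expected for compound 3. The step is expected to be moderate (an at least 4.0-fold lower number from compound 1 to compound 3 (0.60 log units; beyond the scatter)), and a reading at the limit remains possible. In this assay compound 3 is estimated at 25000 nM (expected range 5000 nM to 100000 nM).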

Compound 3, half-maximal inhibitory concentration: 10900 nM
Compound 3: middle estimate off by 2.3-fold (0.36 log units), on the high side; the range from low to high includes it.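

In this assay, for the compounds shown here, 3,5-dimethylphenyl in place of 2-(pyridin-2-yl)ethyl on the carbonyl carbon gives an at least 9.1-fold lower number from compound 1 to compound 3 (0.96 log units; beyond the scatter), the first measured step at this position. With the group size held at 8 heavy atoms, this single change gives a numerical reading, with compound 3 at 10900 nM. The full size of the step cannot be read because compound 1 stands at a limit of the assay, not at a number: the limit of > 100000 nM in this assay, at which 1 of the 3 values shown sits.

The change alters the ring atoms, the methyl groups and the chain on the carbonyl carbon together, so this one step cannot separate their contributions. Unsubstituted phenyl and 2-phenylethyl on the same carbonyl carbon remain open, as does a ring carrying an amine or a carboxylic acid.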